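This account rests on a few compounds, and the source may have more. Where it says the series, first, only, none or still open, it means among the compounds named here.

Measured compounds in a functional assay on HFL1 cells for antagonist activity at sphingosine 1-phosphate receptor 2 (Homo sapiens), read by ELISA, with a stated time of 24 h; on this read-out lower numbers stand for stronger inhibition and higher numbers for weaker inhibition:
compound 1 `CC(C(=O)O)c1nn(Cc2cn3cc(OCC4CC4)c(Cl)cc3n2)c2ccccc2c1=O` gives 1.3 nM;
compound 2 `C[C@@H](C(=O)O)c1nn(Cc2cn3cc(OCC4CC4)c(Cl)cc3n2)c2ccccc2c1=O` gives 182 nM.

Compound 1 stands lowest of the two numbers; its nearest neighbour is compound 2, reached by a 140-fold higher number from compound 1 to compound 2 (2.15 log units; beyond the scatter). That step rests only on the fact that one of compounds 1 and 2 is drawn with a defined configuration and the other without, at the place where they differ and touches no substituent. Compound 3 `CC(C(=O)O)c1nn(Cc2cn3cc(OCC4CC4)c(C(F)(F)F)cc3n2)c2ccccc2c1=O` differs from compound 1 by trifluoromethyl in place of chloro on an aromatic carbon. Among the compounds with values here, no measured step changes this position, so nothing among the measured pairs bears directly on the replacement; the large stereo-linked step between compound 1 and compound 2 says nothing about a group exchanged on the aromatic ring. Both chloro and trifluoromethyl bring no donors and no acceptors, so the swap is expected to leave the potency in this assay close to that of compound 1, with a step of a 1.5-fold higher number from compound 1 to compound 3 (0.19 log units; within the scatter) that is expected to stay within the scatter. Compound 3 is therefore estimated at 2 nM, with a range from 0.5 nM to 8 nM.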

Compound 3, half-maximal inhibitory concentration: 5 nM
Estimate against measurement, compound 3: 2.5-fold (0.40 log units) below; measured number inside the range.
By their numbers in this assay, from the lowest: compound 1; then compound 3; then compound 2.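

In this assay, the aromatic carbon ortho to a cyclopropylmethoxy group now has a measured step of its own: trifluoromethyl in place of chloro gives a 3.8-fold higher number from compound 1 to compound 3 (0.59 log units; beyond the scatter) on the same shared core. The step is modest but beyond the scatter, so this position does respond to the exchange even though neither group brings a hydrogen-bond donor or acceptor, and chloro gives the lower number of the two. Nothing in the data shown gives a cause for this step.

The compounds shown leave open whether a methyl, a nitrile or an amine on this carbon would stay near compound 1 or move further from it. They also leave open how a defined configuration at the saturated chain carbon would act with trifluoromethyl in place.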